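From Ethyl to tert-Butylcarbamoyl on an Azetidine Nitrogen

The source may hold more compounds than are shown below. What is called first, only, known or untested is meant among the compounds shown, and "the series" means these compounds.

Compound 1 `CCN1CC(NC(=O)[C@@H]2CCCN(S(=O)(=O)c3ccc(S(=O)(=O)N(CC)CC)cc3)C2)C1` was examined in a functional assay on MIA PaCa-2 cells (Homo sapiens) for inhibition, read by MTT assay, with a stated time of 3 days; on this read-out lower numbers stand for stronger inhibition and higher numbers for weaker inhibition. In this assay compound 1 gives only a limit, > 10000 nM. Compound 2 `CCOC(=O)C1CCCCN1S(=O)(=O)c1ccc(S(=O)(=O)N(CC)CC)cc1` likewise gives only a limit in this assay, > 10000 nM. Both values sit at the limit of > 10000 nM in this assay, at which 2 of the 2 values shown sit. Compound 3 `CCN(CC)S(=O)(=O)c1ccc(S(=O)(=O)N2CCC[C@@H](C(=O)NC3CN(C(=O)NC(C)(C)C)C3)C2)cc1` carries (tert-butyl)carbamoyl in place of ethyl on an amine nitrogen in a ring, that is, (tert-butyl)carbamoyl in place of ethyl on an amine nitrogen in a ring. Within the data shown here, no measured pair shows this change, so its size is unknown, and two limits give no footing for a move beyond the scatter. Compound 3 is therefore expected to give about 10000 nM, between 2000 nM and 30000 nM. The expected step is a number no higher from compound 1 to compound 3 (the limit leaves the size open).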

Compound 3, half-maximal inhibitory concentration: > 10000 nM
Compound 3 ended at the assay's limit; the forecaster's own chance of this, stated with the estimate: 65%; the middle value sits exactly at the limit.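

In this assay compound 3 gives only a limit (> 10000 nM). Among these compounds, no step from compound 1 to compound 3 can be read, as both values are limits: (the limit of > 10000 nM in this assay, at which 3 of the 3 values shown sit). The compounds shown leave open whether (tert-butyl)carbamoyl in place of ethyl changes inhibition at all.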